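This account rests on a few compounds, and the source may have more. Where it says the series, first, only, none or still open, it means among the compounds named here.

Of the compounds shown here, three sharing one core have been measured in an assay on isolated protein for inhibition of thyroid hormone receptor beta (Homo sapiens), read by fluorescence, with a stated time of 30 min; on this read-out higher numbers stand for weaker inhibition and lower numbers for stronger inhibition. Compound 1 `CCCN(CC1CCOC1)C(=O)c1cc(C)c2oc(NCc3cccc(Cl)c3)nc2c1` gives 35 nM in this assay, compound 2 `COc1cc(C(=O)N2CC[C@@H](O)[C@H](C)C2)cc2nc(NCc3cccc(Cl)c3)oc12` gives 10 nM, and compound 3 `COc1cc(C(=O)N2CCC(O)C(C)C2)cc2nc(NCc3cccc(Cl)n3)oc12` gives 580 nM. Compound 3 thus carries the highest number of the three; compound 1 stands nearer to it and compound 2 furthest away, and both gaps lie beyond the scatter of repeat measurements. Compound 4 `COc1cc(C(=O)N2CCC(O)C(C)C2)cc2nc(NC3(c4cccc(Cl)c4)CC3)oc12` is not yet measured. It differs from compound 3 in one place: 1-(3-chlorophenyl)cyclopropyl in place of (6-chloropyridin-2-yl)methyl on a nitrogen on an aromatic ring. Compound 2 gives 10 nM with a 3-chlorophenyl group at this position, so a lower number for compound 4 is expected. The expected step is a 19-fold lower number from compound 3 to compound 4 (1.29 log units; beyond the scatter). Compound 4 is estimated at 30 nM, within a likely range from 8 nM to 120 nM.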

Compound 4, half-maximal inhibitory concentration: 120 nM
Estimate against measurement, compound 4: 4.0-fold (0.60 log units) below, and the stated range covers the measured number.
By their numbers in this assay, from the lowest: compound 2; then compound 1; then compound 4; then compound 3.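

In this assay, among these compounds, replacing (6-chloropyridin-2-yl)methyl with 1-(3-chlorophenyl)cyclopropyl on the nitrogen gives a 4.8-fold lower number from compound 3 to compound 4 (0.68 log units; beyond the scatter), the first direct reading of a single change at this position. The swap alters both the aromatic ring and the cyclopropyl-containing link at once, so the step cannot be divided between them. No measurement here bears on why the number moves. Still open, as far as these compounds go, is how a 1-(6-chloropyridin-2-yl)cyclopropyl group would read at this nitrogen, since it would keep the pyridine ring while changing only the link.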